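Solubility notes on a benzyl-for-phenyl step

This account rests on a few compounds, and the source may have more. Where it says the series, first, only, none or still open, it means among the compounds named here.

Measured so far in a physicochemical assay for solubility, with a stated time of 18 h, at pH 7.4; on this read-out higher numbers stand for higher solubility and lower numbers for lower solubility:
- compound 1, `COc1ccc(F)cc1CNCCCNc1ccnc2cc(CCC(C)C)ccc12`: 4200 nM
- compound 2, `COc1ccc(F)cc1CNCCCNc1ccnc2cc(Cc3ccc(F)cc3Cl)ccc12`: 4200 nM
- compound 3, `COc1ccc(F)cc1CNCCCNc1ccnc2cc(-c3ccccc3)ccc12`: 32000 nM

Compound 3 stands highest of the three in this assay, through a 7.6-fold higher number from compound 1 to compound 3 (0.88 log units; beyond the scatter) and a 7.6-fold higher number from compound 2 to compound 3 (0.88 log units; beyond the scatter); compound 1 and compound 2 sit together, with no change at the digits printed from compound 1 to compound 2 (within the scatter).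

Compound 4 is `COc1ccc(F)cc1CNCCCNc1ccnc2cc(Cc3ccccc3)ccc12`. Relative to compound 3 the change is benzyl in place of phenyl on an aromatic carbon.

The step that bears most directly is a 7.6-fold higher number from compound 2 to compound 3 (0.88 log units; beyond the scatter), read backwards: a substituted benzyl in place of phenyl lowered the number. The step of no change at the digits printed from compound 1 to compound 2 (within the scatter) adds little. An unsubstituted benzyl is therefore expected to fall between the two, as a drop of about a 2.7-fold lower number from compound 3 to compound 4 (0.43 log units; beyond the scatter). Compound 4 is estimated at 12000 nM, in the range 4000 nM to 36000 nM.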

Compound 4, solubility: 4200 nM
Compound 4: the middle estimate sits 2.9-fold (0.46 log units) above what was measured; measured number inside the range.
By their numbers in this assay, from the lowest: compounds 1, 2 and 4 (each within the scatter of the next); then compound 3.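

At this aromatic carbon, benzyl in place of phenyl alone gives the whole gap (a 7.6-fold lower number from compound 3 to compound 4 (0.88 log units; beyond the scatter)), so the chloro and fluoro substituents of compound 2 are not needed for it. What the saturated chain carbon carries makes no difference among these compounds (no change at the digits printed from compound 2 to compound 4 (within the scatter); no change at the digits printed from compound 1 to compound 4 (within the scatter)), which leaves compound 3, with its phenyl directly on the aromatic carbon, alone at the high end of this assay. No measurement at hand explains this step.

Going by these compounds, it remains open whether a substituted phenyl, a pyridine or an amine on this aromatic carbon would stand with compound 3 or with compound 4.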